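Swapping imidazolyl for cyclohexyl in compound 4

A few compounds are considered here, and "the series" means these few. Any claim that something is new, unique, unknown or untested is made for them only; others in the source may bear on it.

In a functional assay on U-251 cells (Homo sapiens) for inhibition, read by sulforhodamine B assay, with a stated time of 72 h (a lower number here means that less compound is needed, a higher number that more compound is needed for the effect), compound 3 (`O=C(/C=C/c1ccc([N+](=O)[O-])o1)c1ccc(-n2ccnc2)cc1`) stands at 22600 nM and so within the scatter of compound 1 (`O=C(/C=C/c1ccc([N+](=O)[O-])o1)c1ccc(I)cc1`) at 12500 nM as their step (a 1.8-fold higher number from compound 1 to compound 3 (0.26 log units; within the scatter)) shows. Compound 2 (`CCCCc1ccc(C(=O)/C=C/c2ccc([N+](=O)[O-])o2)cc1`) reads 3900 nM with a clear gap (a 5.8-fold higher number from compound 2 to compound 3 (0.76 log units; beyond the scatter)) to compound 3. Compound 4 (`O=C(/C=C/c1ccc([N+](=O)[O-])o1)c1ccc(C2CCCCC2)cc1`) carries cyclohexyl in place of 1H-imidazol-1-yl on an aromatic carbon para to a large group. Among the compounds with values here, no cyclohexyl compound has been measured, so butyl in compound 2 is the nearest guide, and iodo to butyl also lowered the number (a 3.2-fold lower number from compound 1 to compound 2 (0.51 log units; beyond the scatter)) in this series. In this assay a modest downward step (a 4.5-fold lower number from compound 3 to compound 4 (0.66 log units; beyond the scatter)) beyond the scatter is therefore expected. Compound 4 is estimated at 5000 nM (range 2000 nM to 12500 nM).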

Compound 4, half-maximal effective concentration: 4400 nM
The estimate for compound 4 lay 1.1-fold (0.06 log units) above the measured number; low and high end bracket the measured number.
By their numbers in this assay, from the lowest: compounds 2 and 4 (each within the scatter of the next); then compounds 1 and 3 (each within the scatter of the next).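

With cyclohexyl, a ring at this position no longer keeps the number high: in this assay the change from 1H-imidazol-1-yl gives a 5.1-fold lower number from compound 3 to compound 4 (0.71 log units; beyond the scatter) and the change from iodo gives a 2.8-fold lower number from compound 1 to compound 4 (0.45 log units; beyond the scatter) in the same direction. Cyclohexyl and butyl cannot be told apart, with a 1.1-fold higher number from compound 2 to compound 4 (0.05 log units; within the scatter) here, so these two carbon-only groups share the low end of the series. Nothing measured here explains the gap to 1H-imidazol-1-yl. From the compounds shown here alone, whether a longer chain such as octyl would lower the number further remains open, as does how an amine or a carboxylic acid would read at this position.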